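Swapping Fluoro for Methoxy on a Stilbene-like Core

A few compounds are considered here, and "the series" means these few. Any claim that something is new, unique, unknown or untested is made for them only; others in the source may bear on it.

For the measured compounds named here, compound 1 `COc1cccc(/C=C/c2ccccc2F)c1` is the only one of three measured compounds to give a number in an assay on HepG2 cells for activation of nuclear factor erythroid 2-related factor 2 (Homo sapiens), read by a luciferase reporter, with a stated time of 5 h (on this read-out lower numbers stand for an effect already at smaller amounts and higher numbers for an effect only at larger amounts of compound), where compound 1 gives 3800 nM. Compound 2 `COc1ccc(/C=C/c2ccc(F)c(F)c2)cc1` reaches only a limit of this assay, > 15000 nM. Compound 3 `Fc1ccc(/C=C/c2ccc(F)c(F)c2)cc1` likewise gives only a limit, > 15000 nM. The change from compound 3 to compound 2, (methoxy in place of fluoro on an aromatic carbon), therefore makes a step that the two limits leave unreadable from compound 3 to compound 2, since both values sit at the limit of > 15000 nM in this assay, at which 2 of the 3 values shown sit. How the core of compound 1 differs from that of compound 3 is not broken down here.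

Compound 4 `COc1cccc(/C=C/c2ccccc2OC)c1` arises from compound 1 by the same kind of change, (methoxy in place of fluoro on an aromatic carbon), here ortho to a large group rather than para to it. With the earlier step unreadable, the expected step of a 1.1-fold higher number from compound 1 to compound 4 (0.02 log units; within the scatter) rests only on compound 1 at 3800 nM. Compound 4 is estimated at 4000 nM, between 1500 nM and 12000 nM.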

Compound 4, half-maximal effective concentration: 4400 nM
Compound 4: middle estimate off by 1.1-fold (0.04 log units), on the low side; measured number inside the range.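

Methoxy in place of fluoro on an aromatic carbon, ortho to a large group, gives in this assay a 1.2-fold higher number from compound 1 to compound 4 (0.06 log units; within the scatter), so on this core and at this place the swap leaves the read-out within the usual scatter. The same kind of change from compound 3 to compound 2 cannot be read, as each of these two compounds gives only a limit of the assay and not a number: the limit of > 15000 nM in this assay, at which 2 of the 4 values shown sit. This single readable step therefore shows what happens on one core, but not whether the result carries over to another core.

Still open is how an amine or a carboxylic acid would read at the same place; among the compounds shown, only fluoro and methoxy stand there. Also open, on these data alone, is what numbers compound 2 and compound 3 would give in place of their limits.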